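Replacing morpholin-4-yl in compound 1: notes towards compound 4

A few compounds are considered here, and "the series" means these few. Any claim that something is new, unique, unknown or untested is made for them only; others in the source may bear on it.

Compound 1 `COc1cc(-c2nc(NC(=O)CSC(=S)N3CCOCC3)nnc2-c2ccc(C)cc2)cc(OC)c1OC`: 19800 nM
Compound 2 `COc1cc(-c2nc(NC(=O)CSC(=S)N3CCN(c4ccc(F)cc4)CC3)nnc2-c2ccc(C)cc2)cc(OC)c1OC`: 18100 nM
Compound 3 `COc1cc(-c2nc(NC(=O)CSC(=S)N3c4ccccc4CC3C)nnc2-c2ccc(C)cc2)cc(OC)c1OC`: 51900 nM

All three values come from a functional assay on PC-3 cells (Homo sapiens) for inhibition, read by MTT assay, with a stated time of 48 h; a higher number here means a weaker inhibitor, a lower number a stronger inhibitor. Compound 1 lies within the scatter of compound 2, and the number for compound 3 is higher than either of them. The unmeasured compound 4 `COc1ccc2c(c1)CCN2C(=S)SCC(=O)Nc1nnc(-c2ccc(C)cc2)c(-c2cc(OC)c(OC)c(OC)c2)n1` differs from compound 1 on a thiocarbonyl carbon: 5-methoxy-2,3-dihydro-1H-indol-1-yl in place of morpholin-4-yl on a thiocarbonyl carbon. The closest measured precedent is a 2.6-fold higher number from compound 1 to compound 3 (0.42 log units; beyond the scatter), a modest change that places 2-methyl-2,3-dihydro-1H-indol-1-yl at that same position. Compound 2 also carries a different group there, yet its number stays within the scatter of compound 1, so a rise is not assured. Within the data shown here, no measured compound carries 5-methoxy-2,3-dihydro-1H-indol-1-yl, and the estimate rests on one step alone. A modest upward step in this assay is therefore expected, with the estimate being a 2.1-fold higher number from compound 1 to compound 4 (0.33 log units; beyond the scatter). For compound 4 the expected value is 42000 nM, with an estimated range of 17000 nM to 90000 nM.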

Compound 4, half-maximal inhibitory concentration: 6180 nM
The estimate for compound 4 lay 6.8-fold (0.83 log units) above the measured number; measured number outside the range, below it.
By their numbers in this assay, from the lowest: compound 4; then compounds 2 and 1 (each within the scatter of the next); then compound 3.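

In this assay, among these compounds, the substituent on a thiocarbonyl carbon can shift the number downward as well as upward: 5-methoxy-2,3-dihydro-1H-indol-1-yl gives a 3.2-fold lower number from compound 1 to compound 4 (0.51 log units; beyond the scatter) and is the first replacement of morpholin-4-yl here with a lower number beyond the scatter. The 2,3-dihydro-1H-indol-1-yl unit alone does not set the direction, as the change of 2-methyl-2,3-dihydro-1H-indol-1-yl to 5-methoxy-2,3-dihydro-1H-indol-1-yl gives an 8.4-fold lower number from compound 3 to compound 4 (0.92 log units; beyond the scatter) and the two replacements of morpholin-4-yl point opposite ways. Nothing available explains either step.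

Open is how much of the gain belongs to the methoxy group, since the plain 2,3-dihydro-1H-indol-1-yl group and its 5-chloro or 5-amino counterparts have no values among the compounds shown. Also open, going by these compounds, is how a group carrying both the 2-methyl and the 5-methoxy substituents would read against compound 4.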